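A few compounds are considered here, and "the series" means these few. Any claim that something is new, unique, unknown or untested is made for them only; others in the source may bear on it.

Measured compounds in an assay on cells for inhibition of matrix metalloproteinase-9 (Homo sapiens), read by fluorescence, with stated times of 15 min and 4 h; on this read-out higher numbers stand for weaker inhibition and lower numbers for stronger inhibition:
- compound 1 `O=C(CCc1ccccc1)Nc1cccc(-c2nc3ccccc3[nH]2)c1` — compound 1 gives 68000 nM
- compound 2 `Cc1cccc2nc(-c3cccc(NC(=O)CCc4ccccc4)c3)[nH]c12` — compound 2 gives 60000 nM
- compound 3 `Cc1cccc2nc(-c3cccc(NC(=O)CCCc4ccccc4)c3)[nH]c12` — compound 3 gives 38600 nM

Compound 3 has the lowest number of the three, but its separation from the others is small: a 1.6-fold lower number from compound 2 to compound 3 (0.19 log units; within the scatter) and the gap to compound 1 are both within the scatter, so no ordering can be read among them.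

Compound 4 `O=C(CCCc1ccccc1)Nc1cccc(-c2nc3ccccc3[nH]2)c1` differs from compound 3 by hydrogen in place of methyl on an aromatic carbon. Among the compounds with values here, the one measured step that bears on this change is the reverse one, a 1.1-fold lower number from compound 1 to compound 2 (0.05 log units; within the scatter), where the methyl enters on the same aromatic carbon; it moved the number by an amount within the scatter. Compound 4 is also compound 1 extended by one chain carbon, the same change as a 1.6-fold lower number from compound 2 to compound 3 (0.19 log units; within the scatter), again within the scatter. Within the data shown here, no step in this assay has yet moved beyond the scatter, so no shift is expected here either.

Compound 4 is therefore expected to give about 42000 nM (range 20000 nM to 85000 nM), an estimated step of a 1.1-fold higher number from compound 3 to compound 4 (0.04 log units; within the scatter) from compound 3 to compound 4 that lies within the scatter.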

Compound 4, half-maximal inhibitory concentration: 43000 nM
Beside the measured number, compound 4's estimate is 1.0-fold (0.01 log units) below it; the range from low to high includes it.
By their numbers in this assay, from the lowest: compounds 3, 4, 2 and 1 (each within the scatter of the next).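

In this assay, hydrogen in place of methyl on the aromatic carbon gives a 1.1-fold higher number from compound 3 to compound 4 (0.05 log units; within the scatter), so this change has now been read with both chain lengths and stays within the scatter each time: the same change on two cores in this assay, a 1.1-fold lower number (0.05 log units; within the scatter) from compound 1 to compound 2 and a 1.1-fold lower number (0.05 log units; within the scatter) from compound 4 to compound 3, 1.0-fold (0.01 log units) apart, within the scatter of two such steps. Benzyl in place of phenyl on the saturated chain carbon gives a 1.6-fold lower number from compound 1 to compound 4 (0.20 log units; within the scatter), so the chain change has likewise been read on both cores and also stays within the scatter: the same change on two cores in this assay, a 1.6-fold lower number (0.19 log units; within the scatter) from compound 2 to compound 3 and a 1.6-fold lower number (0.20 log units; within the scatter) from compound 1 to compound 4, 1.0-fold (0.01 log units) apart, within the scatter of two such steps. Within the data shown here, the four compounds now form a closed set in which each change appears twice and no step leaves the scatter.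

The compounds shown leave open whether any change at these two places can move the number beyond the scatter. A chlorine or a methoxy on that aromatic carbon, or a longer chain, would test this.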